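This account rests on a few compounds, and the source may have more. Where it says the series, first, only, none or still open, it means among the compounds named here.

Measured compounds:
Compound 1 `CCN(CC)CCCn1c(=O)c(=Cc2ccccc2O)s/c1=C1\C(=O)Nc2ccc(Br)cc21`: in a functional assay on MDA-MB-231 cells (Homo sapiens) for inhibition, read by MTT assay, with a stated time of 72 h (on this read-out lower numbers stand for stronger inhibition and higher numbers for weaker inhibition), compound 1 gives 19900 nM.
Compound 2 `CN(C)CCn1c(=O)c(=Cc2ccc(F)cc2F)s/c1=C1\C(=O)Nc2cc(F)ccc21`: in this assay compound 2 gives 8440 nM.
Compound 3 `CN(C)CCn1c(=O)c(=Cc2ccc(F)c(F)c2)s/c1=C1\C(=O)Nc2ccc(F)cc21`: in this assay compound 3 gives 9480 nM.

Compound 1 stands highest of the three numbers in this assay; compound 3 is its nearest neighbour and compound 2 the furthest, both with lower numbers and both beyond the scatter. Within the data shown here, no two measured compounds differ in one place only, so no single step is known. Compound 4 `CCN(CC)CCCn1c(=O)c(=Cc2ccccc2O)s/c1=C1\C(=O)Nc2ccccc21` differs from compound 1 by hydrogen in place of bromo on an aromatic carbon. Among the measured compounds shown here, with no measured precedent for this change, the step of a 1.3-fold higher number from compound 1 to compound 4 (0.10 log units; within the scatter) is expected to be small and not beyond the scatter, leaning toward a slightly higher number. Compound 4 is therefore estimated at 25000 nM, within a range from 10000 nM to 60000 nM.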

Compound 4, half-maximal inhibitory concentration: > 200000 nM
Compound 4 ended at the assay's limit; the forecaster's own chance of this, stated with the estimate: 15%; middle value at least 8.0-fold (0.90 log units) from the limit.
By their numbers in this assay, from the lowest: compounds 2 and 3 (each within the scatter of the next); then compound 1. At a limit, above all of these: compound 4.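

In this assay compound 4 gives > 200000 nM, which is a limit and not a number. Among these compounds, this gives the first single change that can be read: hydrogen in place of bromo on this aromatic carbon is an at least 10-fold higher number from compound 1 to compound 4 (1.00 log units; beyond the scatter), so the bromo at this position matters in the frame of compound 1. How large the step truly is remains unknown: the limit of > 200000 nM in this assay, at which 1 of the 4 values shown sits.

The compounds shown leave open whether chloro or methoxy at this position would keep the number of compound 1. They also leave open whether the same change would matter as much with the other substituents of compound 2 and compound 3.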